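Fluoro for Cyano: Expected Tolerance of Compound 3

This account rests on a few compounds, and the source may have more. Where it says the series, first, only, none or still open, it means among the compounds named here.

Compound 1 `O=C1/C(=N\Nc2ccc(Br)cc2)c2ccccc2N1Cc1cn(O[C@@H]2O[C@H](CO)[C@H](O)[C@H](O)[C@H]2O)nn1` and compound 2 `N#Cc1ccc(N/N=C2\C(=O)N(Cc3cn(O[C@@H]4O[C@H](CO)[C@H](O)[C@H](O)[C@H]4O)nn3)c3ccccc32)cc1` share one core and differ at a single aromatic carbon. In an ADME assay on Vero cells (Chlorocebus sabaeus) for cytotoxicity, read by fluorescence and resazurin assay, with a stated time of 3 days (a higher number here means that more compound is tolerated, a lower number that less compound is tolerated), compound 1 gives 91500 nM, and compound 2 gives 93700 nM. Compound 2 thus holds the highest of the two numbers, with compound 1 nearest, but the step of a 1.0-fold higher number from compound 1 to compound 2 (0.01 log units; within the scatter) shows that the two values lie within the scatter of each other. Compound 3 `O=C1/C(=N\Nc2ccc(F)cc2)c2ccccc2N1Cc1cn(O[C@@H]2O[C@H](CO)[C@H](O)[C@H](O)[C@H]2O)nn1` is the next member of the set: fluoro in place of cyano on an aromatic carbon. Among the measured compounds shown here, the only measured step that bears on this change is the one from compound 1 to compound 2, which exchanged one group for another on the same aromatic carbon and left the number essentially unchanged. On that basis no step beyond the scatter is expected for compound 3, and the expected step is a 1.0-fold lower number from compound 2 to compound 3 (0.01 log units; within the scatter). Compound 3 is estimated at 92000 nM, with a range from 46000 nM to 184000 nM.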

Compound 3, half-maximal cytotoxic concentration: 92100 nM
For compound 3 the middle estimate is 1.0-fold (0.00 log units) below the measured one; measured number inside the range.
By their numbers in this assay, from the lowest: compounds 1, 3 and 2 (each within the scatter of the next).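

In this assay fluoro on this aromatic carbon, para to a large group, gives a 1.0-fold lower number from compound 2 to compound 3 (0.01 log units; within the scatter) and a 1.0-fold higher number from compound 1 to compound 3 (0.00 log units; within the scatter) so that neither exchange moves the number beyond the scatter. Where the earlier compounds compared only bromo with cyano, the position now carries three different groups with values that stay within the scatter of one another, including a swap of the two heavy atoms and triple bond of cyano for the single heavy atom of fluoro. Nothing available bears on why these values coincide. As far as these compounds go, what an amine, a carboxylic acid or a longer alkyl chain on this carbon would do to the tolerated concentration remains open. Also open, from the compounds shown here alone, is whether a change elsewhere on the shared core would move the number, since these compounds differ only at this one carbon.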